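Aryl replacement on the shared core of compound 1

The source may report more compounds than this note shows. Statements on the series, on what has been measured and on what is new or still open speak of the compounds shown alone.

Compound 1, `COc1cc(-c2ccnc3cc(-c4ccc(C(C)(C)C)cc4)nn23)cc(OC)c1OC`, stands at the edge of what a functional assay on A549 cells (Homo sapiens) for inhibition, read by CCK-8 assay, with a stated time of 48 h (a higher number here means a weaker inhibitor, a lower number a stronger inhibitor), resolves: in this assay compound 1 gives > 10000 nM, which is a limit of the assay and not a number, as noted in the limit of > 10000 nM in this assay, at which 1 of the 2 values shown sits. Compound 2, `COc1cc(-c2ccnc3cc(-c4ccc(-c5cnn(C)c5)cc4)nn23)cc(OC)c1OC`, gives 1150 nM in this assay. Going by the values given here, the single measured step, an at least 8.6-fold lower number from compound 1 to compound 2 (0.93 log units; beyond the scatter), is the only guide for the new compound. Compound 3, `COc1cc(-c2ccnc3cc(-c4ccc5cnn(C)c5c4)nn23)cc(OC)c1OC`, differs from compound 1 by 1-methyl-1H-indazol-6-yl in place of 4-(tert-butyl)phenyl on an aromatic carbon. This change again removes the 4-(tert-butyl)phenyl group and, as in compound 2, brings in a five-membered aromatic ring with 2 hetero atoms, here as 1-methyl-1H-indazol-6-yl. A step in the same direction and of comparable size is therefore expected, an at least 6.6-fold lower number from compound 1 to compound 3 (0.82 log units; beyond the scatter). Compound 3 is accordingly estimated at 1500 nM in this assay, with a likely range from 400 nM to 6000 nM.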

Compound 3, half-maximal inhibitory concentration: 233 nM
For compound 3 the middle estimate is 6.4-fold (0.81 log units) above the measured one; measured number outside the range, below it.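

In this assay, a second replacement of 4-(tert-butyl)phenyl at this position also lowers the number, now with 1-methyl-1H-indazol-6-yl: an at least 42-fold lower number from compound 1 to compound 3 (1.63 log units; beyond the scatter). That step has only a lower bound, since compound 1 gives > 10000 nM, which is a limit of the assay and not a number: the limit of > 10000 nM in this assay, at which 1 of the 3 values shown sits. Compound 2 gives 1150 nM and compound 3 gives 233 nM, so the outcome at this position depends on which group enters and not only on the loss of 4-(tert-butyl)phenyl.

The compounds shown leave open whether both ring nitrogens and the methyl of 1-methyl-1H-indazol-6-yl contribute to this result. Also open, from the compounds shown here alone, is how an amine or a carboxylic acid carried on the same position would read in this assay.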